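Bromo-to-hydrogen change carried across two nitrophenyl isomers

The compounds below may be only part of what the source reports. "The series", "measured", "known", "first", "only" and "open" are said of these compounds alone.

Measured so far:
Compound 1 `O=C(Nc1ccc([N+](=O)[O-])cc1)Nc1nc(-c2cc3cc(Br)ccc3o2)cs1`: in a physicochemical assay, with a stated time of 6 min (a lower number here means a stronger inhibitor, a higher number a weaker inhibitor), compound 1 gives > 200000 nM, which is a limit of the assay and not a number.
Compound 2 `O=C(Nc1ccc([N+](=O)[O-])cc1)Nc1nc(-c2cc3ccccc3o2)cs1`: in this assay compound 2 gives 19300 nM.
Compound 3 `O=C(Nc1nc(-c2cc3cc(Br)ccc3o2)cs1)Nc1ccccc1[N+](=O)[O-]`: in this assay compound 3 gives 166000 nM.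

Compound 1 and compound 3 differ only in how the same atoms are joined: 2-nitrophenyl in place of 4-nitrophenyl on an amide-type nitrogen. The resulting step is an at least 1.2-fold lower number from compound 1 to compound 3 (0.08 log units; that floor lies within the scatter), bounded by the limit of > 200000 nM in this assay, at which 1 of the 3 values shown sits.

The change from compound 1 to compound 2 is hydrogen in place of bromo on an aromatic carbon, and it gives an at least 10-fold lower number from compound 1 to compound 2 (1.01 log units; beyond the scatter).

Compound 4 `O=C(Nc1nc(-c2cc3ccccc3o2)cs1)Nc1ccccc1[N+](=O)[O-]` is not yet measured. It stands to compound 3 as compound 2 stands to compound 1: hydrogen in place of bromo on an aromatic carbon, the same change at the same place. The expected step is a 9.8-fold lower number from compound 3 to compound 4 (0.99 log units; beyond the scatter) in this assay, resting on an at least 10-fold lower number from compound 1 to compound 2 (1.01 log units; beyond the scatter), whose true size is open since it starts from the limit of > 200000 nM in this assay, at which 1 of the 3 values shown sits. Compound 4 is estimated at 17000 nM in this assay, expected between 6000 nM and 60000 nM.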

Compound 4, half-maximal inhibitory concentration: 20300 nM
Beside the measured number, compound 4's estimate is 1.2-fold (0.08 log units) below it; the range from low to high includes it.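

In this assay hydrogen in place of bromo gives an 8.2-fold lower number from compound 3 to compound 4 (0.91 log units; beyond the scatter) and so the direction seen with the 4-nitrophenyl compounds holds on the 2-nitrophenyl compounds, though two pairs are all that support this. Without bromo, 2-nitrophenyl in place of 4-nitrophenyl gives a 1.1-fold higher number from compound 2 to compound 4 (0.02 log units; within the scatter) and the two compounds cannot be told apart. The size of the change in the two pairs cannot be compared, since the other pair starts from compound 1, whose value is a limit and not a number: the limit of > 200000 nM in this assay, at which 1 of the 4 values shown sits.

Replacements of bromo other than hydrogen, such as chloro or an amine on that aromatic carbon, remain open. So does a carboxylic acid in place of the nitro group.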